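The source may hold more compounds than are shown below. What is called first, only, known or untested is meant among the compounds shown, and "the series" means these compounds.

For the measured compounds named here, compound 2 `Cc1ccccc1NC(=O)OC(CCN(C)C)c1ccc(Cl)cc1` gives 3890 nM in an assay on NIH3T3 cells with Urotensin-2 receptor (Homo sapiens) as the target (on this read-out lower numbers stand for an effect already at smaller amounts and higher numbers for an effect only at larger amounts of compound), and stands highest of the two numbers so far. Going by the values given here, its only neighbour is compound 1 `Cc1ccc(C)c(C(=O)OC(CCN(C)C)c2ccc(Cl)cc2)c1`, which in this assay gives 1860 nM; the step from compound 1 to compound 2 is a 2.1-fold higher number from compound 1 to compound 2 (0.32 log units; beyond the scatter). Compound 3 `COc1cccc(NC(=O)OC(CCN(C)C)c2ccc(Cl)cc2)c1` differs from compound 2 by 3-methoxyphenyl in place of 2-methylphenyl on an amide-type nitrogen. Among the compounds with values here, no measured step exchanges one substituted phenyl for another on the amide-type nitrogen; the single step known alters the group on the carbonyl carbon and bears only loosely on this change. The expected step is therefore small, a 1.3-fold lower number from compound 2 to compound 3 (0.11 log units; within the scatter), with compound 3 estimated at 3000 nM, range 1000 nM to 10000 nM.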

Compound 3, half-maximal effective concentration: 1120 nM
Estimate against measurement, compound 3: 2.7-fold (0.43 log units) above; the range from low to high includes it.
By their numbers in this assay, from the lowest: compounds 3 and 1 (each within the scatter of the next); then compound 2.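

Exchanging one substituted phenyl for another on the amide-type nitrogen is not neutral in this assay: 3-methoxyphenyl in place of 2-methylphenyl gives a 3.5-fold lower number from compound 2 to compound 3 (0.54 log units; beyond the scatter). The two groups differ both in substituent and in its ring number, so this single step cannot assign the change to either. No available evidence accounts for the step.

The compounds shown leave open how 3-methylphenyl or 2-methoxyphenyl would read on this nitrogen, which would separate those two features. From the compounds shown here alone, an unsubstituted phenyl or a 3-chlorophenyl there also remains open.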